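Swapping the terminal amine ring in a quinoline ether series

The compounds below may be only part of what the source reports. "The series", "measured", "known", "first", "only" and "open" are said of these compounds alone.

Measured compounds in a functional assay on MKN-45 cells (Homo sapiens) for inhibition, read by MTT assay, with a stated time of 72 h; on this read-out lower numbers stand for stronger inhibition and higher numbers for weaker inhibition:
- compound 1 `COc1cc2c(Oc3ccc(NC(=O)c4nn(-c5ccccc5)c(=O)cc4C)cc3F)ccnc2cc1OCCCN1CCCC1`: 120 nM
- compound 2 `Cc1cc(=O)n(-c2ccccc2)nc1C(=O)Nc1ccc(Oc2ccnc3cc(OCCCN4CCC(C)CC4)ccc23)c(F)c1`: 120 nM
- compound 3 `COc1cc2c(Oc3ccc(NC(=O)c4nn(-c5ccccc5C)c(=O)cc4C)cc3F)ccnc2cc1OCCCN1CCCC1`: 760 nM

Compound 3 gives the highest number of the three in this assay; compound 1 and compound 2 sit together with lower numbers. Going by the values given here, the only single-point step among the measured compounds is a 6.3-fold higher number from compound 1 to compound 3 (0.80 log units; beyond the scatter), which sets compound 3 apart from compound 1.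

Compound 4 `COc1cc2c(Oc3ccc(NC(=O)c4nn(-c5ccccc5C)c(=O)cc4C)cc3F)ccnc2cc1OCCCN1CCC(C)CC1` has not yet been measured. It keeps the methyl-bearing phenyl of compound 3 and changes the chain end: 4-methylpiperidin-1-yl in place of pyrrolidin-1-yl on a saturated chain carbon, three bonds along the chain from an oxygen on an aromatic ring. Among the compounds with values here, no measured step isolates this change. Compound 1 and compound 2 do differ in the same pair of rings, but also in a methoxy group, and their values in this assay are identical, which offers no sign that the ring swap on its own moves the number. On that slim basis the expectation is for compound 4 to stay close to compound 3, with the expected step of a 1.1-fold lower number from compound 3 to compound 4 (0.04 log units; within the scatter) not beyond the scatter. Compound 4 is therefore estimated at 700 nM, within a range from 300 nM to 1800 nM.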

Compound 4, half-maximal inhibitory concentration: 1290 nM
Compound 4: middle estimate off by 1.8-fold (0.27 log units), on the low side; the measured number falls inside the stated range.
By their numbers in this assay, from the lowest: compounds 1 and 2 (each within the scatter of the next); then compounds 3 and 4 (each within the scatter of the next).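

In this assay, going by these compounds alone, putting 4-methylpiperidin-1-yl in place of pyrrolidin-1-yl on a saturated chain carbon, three bonds along the chain from an oxygen on an aromatic ring, gives a 1.7-fold higher number from compound 3 to compound 4 (0.23 log units; within the scatter), and this is the first reading of the ring swap with nothing else in the molecule altered. With the methyl-bearing phenyl in place, the two amine rings cannot be told apart in this test, even though the ring that enters is six-membered and carries seven heavy atoms, whereas the one that leaves is five-membered and carries five. No measurement is available that would explain this outcome.

The swap has been read on the methyl-bearing phenyl only, since compound 1 and compound 2 also differ in a methoxy group, so its effect with the plain phenyl remains an open question. On these data alone, it also remains open whether this position would accept amine rings with a second hetero atom, such as morpholin-4-yl or 4-methylpiperazin-1-yl, or an open-chain amine such as dimethylamino, just as readily.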